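Swapping the amine-bearing chain on a shared core

This account rests on a few compounds, and the source may have more. Where it says the series, first, only, none or still open, it means among the compounds named here.

Compound 1 `c1ccc2c(c1)CN[C@@H](CN(CCCCNC1CCNCC1)[C@H]1CCCc3cccnc31)C2` and compound 2 `CC(C)(N)CCCN(C[C@H]1Cc2ccccc2CN1)[C@H]1CCCc2cccnc21` share a core and differ only in the chain carried by the amine nitrogen. In a functional assay on cells for antagonist activity at C-X-C chemokine receptor type 4 (Homo sapiens), read by fluorescence and calcium flux, with stated times of 25 min and 90 s (on this read-out higher numbers stand for weaker inhibition and lower numbers for stronger inhibition), compound 1 gives 63.4 nM, while compound 2 gives 24.6 nM. Among the measured compounds shown here, the one change measured here, a 2.6-fold lower number from compound 1 to compound 2 (0.41 log units; beyond the scatter), moved the number by a modest but real amount. For the measured compounds named here, on the two numbers seen so far, compound 2 stands lowest, with compound 1 as its only neighbour.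

Compound 3 `C(=C/CN(C[C@H]1Cc2ccccc2CN1)[C@H]1CCCc2cccnc21)\CNCc1cccnc1` alters the same region again: a group of 11 heavy atoms (9 carbon, 2 nitrogen; one six-membered aromatic ring with 1 hetero atom) in place of a group of 6 heavy atoms (5 carbon, 1 nitrogen; no ring), on a saturated chain carbon bound to an amine nitrogen. Going by the values given here, the only step that bears on this change is the one from compound 1 to compound 2, since it too reshaped the chain on this nitrogen; it showed that such a change can shift the number beyond the scatter, without showing which way a larger group carrying a ring would push. Among the compounds with values here, with no closer precedent, compound 3 is expected to land near the two measured compounds, with the step from compound 2 to compound 3 estimated at a 2.0-fold higher number from compound 2 to compound 3 (0.31 log units; beyond the scatter). The estimate for compound 3 in this assay is 50 nM, with a range from 15 nM to 170 nM.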

Compound 3, half-maximal inhibitory concentration: 92.8 nM
Compound 3: the middle estimate sits 1.9-fold (0.27 log units) below what was measured; the range from low to high includes it.
By their numbers in this assay, from the lowest: compound 2; then compounds 1 and 3 (each within the scatter of the next).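

In this assay, this change now has a direction: putting the larger, ring-bearing group in place of 3-amino-3-methylbutyl gives a 3.8-fold higher number from compound 2 to compound 3 (0.58 log units; beyond the scatter) and so weakens inhibition by a modest amount. Compound 1 also carries a ring-bearing chain, though its ring is non-aromatic, and a 1.5-fold higher number from compound 1 to compound 3 (0.17 log units; within the scatter) leaves compound 1 and compound 3 indistinguishable, so among these three compounds the two chains with a ring read alike and only the ring-free chain of compound 2 gives a clearly lower number. Nothing available here offers a reason for these differences.

Compound 3 brings in its aromatic ring, its double bond and its larger size all at once, so these compounds cannot show which of those features accounts for the step away from compound 2. Also open, from the compounds shown here alone, is how this position would respond to a simple butyl chain ending in an unbranched primary amine, which would show whether the two methyl groups of 3-amino-3-methylbutyl contribute to the lower number of compound 2.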